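From 4-Methoxyphenyl to Bromo: Estimating Compound 4

The source may hold more compounds than are shown below. What is called first, only, known or untested is meant among the compounds shown, and "the series" means these compounds.

Of the compounds shown here, three built on a shared core have been measured in a functional assay on DLD-1 cells (Homo sapiens) for antiproliferative activity, read by CellTiter-Glo, with a stated time of 72 h; on this read-out lower numbers stand for stronger inhibition and higher numbers for weaker inhibition. Within the data shown here, compound 1 `Cc1ccc(S(=O)(=O)N2CCC(N3CCC(C)CC3)CC2)cc1C` gives 24 nM, compound 2 `CC1CCN(C2CCN(S(=O)(=O)c3ccccc3-c3ccc(C(F)(F)F)cc3)CC2)CC1` gives 122 nM, and compound 3 `COc1ccc(-c2ccccc2S(=O)(=O)N2CCC(N3CCC(C)CC3)CC2)cc1` gives 1000 nM, the highest of the three numbers and thus the weakest inhibition of this set; the only single-point step measured was an 8.2-fold higher number from compound 2 to compound 3 (0.91 log units; beyond the scatter). Compound 4 `CC1CCN(C2CCN(S(=O)(=O)c3ccccc3Br)CC2)CC1` differs from compound 3 in one place: bromo in place of 4-methoxyphenyl on an aromatic carbon. Among the measured compounds shown here, no measured step follows this same change. The step of an 8.2-fold higher number from compound 2 to compound 3 (0.91 log units; beyond the scatter) exchanges one substituent for another within the 4-methoxyphenyl that now leaves, so it says little about removing that group altogether. Compound 1, which carries no attached aromatic ring at all, shows the lowest number, which hints that compound 4 could land well below compound 3, though the data cannot confirm this. For compound 4 a value of 100 nM is therefore estimated, expected to fall between 25 nM and 400 nM. That estimate corresponds to an expected step of a 10-fold lower number from compound 3 to compound 4 (1.00 log units; beyond the scatter).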

Compound 4, half-maximal inhibitory concentration: 3 nM
Estimate against measurement, compound 4: 33-fold (1.52 log units) above, and the stated range ends above it.
By their numbers in this assay, from the lowest: compound 4; then compound 1; then compound 2; then compound 3.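

In this assay, a bromo in place of the 4-methoxyphenyl gives a 330-fold lower number from compound 3 to compound 4 (2.52 log units; beyond the scatter), and the step is a 41-fold lower number from compound 2 to compound 4 (1.61 log units; beyond the scatter) when the 4-(trifluoromethyl)phenyl leaves instead, so neither of these attached aromatic rings is needed at this position for a low number. The 2-bromophenyl on the sulfonyl sulfur also outdoes the 3,4-dimethylphenyl with an 8.0-fold lower number from compound 1 to compound 4 (0.90 log units; beyond the scatter) and so ends as the strongest inhibitor of the four. No measurement of any other kind bears on the reason for these gains.

The compounds shown leave open whether bromo itself matters or whether a chloro or a methyl on the same carbon would do as well. They also leave open how an amine or a carboxylic acid would fare there.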